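The compounds below may be only part of what the source reports. "The series", "measured", "known", "first", "only" and "open" are said of these compounds alone.

Of the compounds shown here, three built on a shared core have so far been measured in an assay on CHO cells for displacement of a labelled ligand from muscarinic acetylcholine receptor M5 (Homo sapiens), read by scintillation counting, with a stated time of 2 h; a lower number here means a stronger inhibitor, a higher number a weaker inhibitor. Compound 1 `Cc1ccc(CCCOC(=O)N(c2ccccc2)C2CN3CCC2CC3)cc1F` gives 130 nM, compound 2 `O=C(OCCCc1ccc(F)c(F)c1)N(c1ccccc1)C1CN2CCC1CC2` gives 100 nM, and compound 3 `COc1ccc(CCOC(=O)N(c2ccccc2)C2CN3CCC2CC3)cc1OC` gives 3490 nM, the highest of the three numbers, beyond the scatter from both others. Compound 4 `O=C(OCCCc1ccccc1)N(c1ccccc1)C1CN2CCC1CC2` has not yet been measured in this assay. It differs from compound 3 by benzyl in place of 3,4-dimethoxyphenyl on a saturated chain carbon, two bonds along the chain from an oxygen next to a carbonyl group. Within the data shown here, two measured steps bear on this change: a 27-fold higher number from compound 1 to compound 3 (1.43 log units; beyond the scatter) and a 35-fold higher number from compound 2 to compound 3 (1.54 log units; beyond the scatter), both large, each putting the 3,4-dimethoxyphenyl group in place of a substituted benzyl group. Compound 4 reverses that move, so a large fall in this assay is expected, toward the numbers of compound 1 and compound 2. The estimate for compound 4 is 160 nM, ranging from 50 nM to 550 nM. For compound 4 this estimate means an expected step of a 22-fold lower number from compound 3 to compound 4 (1.34 log units; beyond the scatter).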

Compound 4, inhibition constant: 260 nM
Compound 4: middle estimate off by 1.6-fold (0.21 log units), on the low side, within the range that was stated.
By their numbers in this assay, from the lowest: compounds 2, 1 and 4 (each within the scatter of the next, the first and the last beyond it); then compound 3.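

In this assay, the plain benzyl group without any ring substituent is enough to give the large step away from the 3,4-dimethoxyphenyl group (a 13-fold lower number from compound 3 to compound 4 (1.13 log units; beyond the scatter)). The ring substituents of the two earlier benzyl compounds count for much less: one step is modest (a 2.6-fold higher number from compound 2 to compound 4 (0.41 log units; beyond the scatter)) and the other stays within the scatter (a 2.0-fold higher number from compound 1 to compound 4 (0.30 log units; within the scatter)). Nothing at hand explains these steps.

On these data alone, since this change alters both the chain and the ring, the share of each stays open. A 3,4-dimethoxybenzyl group would separate them, and a longer chain would test how far the trend extends.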